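Orexin-1 antagonist series: aryl ether to anilide swap

The source may report more compounds than this note shows. Statements on the series, on what has been measured and on what is new or still open speak of the compounds shown alone.

Measured so far:
- compound 1, `O=C(c1ccccc1-c1ccccc1)N1CCCCC1CCOc1ccc(F)cc1`: 5.01 nM
- compound 2, `O=C(c1cccc2ccccc12)N1CCCC[C@H]1CCOc1ccc(F)cc1`: 6.31 nM
- compound 3, `O=C(c1ccccc1-c1ccccc1)N1CCCC[C@H]1CCOc1ccc(F)cc1F`: 0.159 nM

In a functional assay on CHO cells for antagonist activity at Orexin/Hypocretin receptor type 1 (Homo sapiens), read by FLIPR (a lower number here means a stronger inhibitor, a higher number a weaker inhibitor), compound 3 gives the lowest number of the three; compound 1 sits a step higher that lies beyond the scatter, and compound 2 further still, also beyond the scatter. Compound 4, `O=C(C[C@@H]1CCCCN1C(=O)c1ccccc1-c1ccccc1)Nc1ccccc1`, is the next candidate. It differs from compound 3 by phenylcarbamoyl in place of (2,4-difluorophenoxy)methyl on a saturated chain carbon bound to a saturated ring carbon. For the measured compounds named here, no measured pair in the set shows this change, so its size is unknown; removing the (2,4-difluorophenoxy)methyl group that marks compound 3 out from compounds 1 and 2 is expected to cost potency, and the step of a 130-fold higher number from compound 3 to compound 4 (2.10 log units; beyond the scatter) is estimated as a clear move toward higher numbers, beyond the scatter. Compound 4 is expected to give about 20 nM, likely between 3 nM and 150 nM.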

Compound 4, inhibition constant: 50.1 nM
Compound 4: the middle estimate sits 2.5-fold (0.40 log units) below what was measured, within the range that was stated.
By their numbers in this assay, from the lowest: compound 3; then compounds 1 and 2 (each within the scatter of the next); then compound 4.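

In this assay the swap to phenylcarbamoyl in place of (2,4-difluorophenoxy)methyl on a saturated chain carbon bound to a saturated ring carbon gives a 320-fold higher number from compound 3 to compound 4 (2.50 log units; beyond the scatter) as a large step. For the compounds shown here, this is the first measured change at this position, and it shows that keeping an aromatic ring of carbon only in the incoming group does not preserve the low number of compound 3. No measurement at hand accounts for the size of this step. The compounds shown leave open whether the amide hydrogen, the carbonyl or the missing fluorine substituents carry the step. A plain phenoxymethyl group, a benzylamine or a longer chain at this position could separate these.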